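The source may report more compounds than this note shows. Statements on the series, on what has been measured and on what is new or still open speak of the compounds shown alone.

Measured so far:
In a functional assay on NCI-H460 cells (Homo sapiens) for antiproliferative activity, read by MTT assay, with a stated time of 72 h (on this read-out lower numbers stand for stronger inhibition and higher numbers for weaker inhibition), compound 1 `CN(C)CCn1cnnc1-c1cc(Oc2ccc(NC(=O)Nc3ccc(F)c(Cl)c3)cc2F)ccn1` gives 1580 nM.
In this assay compound 2 `CN(C)CCn1cnnc1-c1cc(Oc2ccc(NC(=O)Nc3ccc(Cl)cc3Cl)cc2F)ccn1` gives 4350 nM.
In this assay compound 3 `CCN(CC)CCn1cnnc1-c1cc(Oc2ccc(NC(=O)Nc3ccc(F)c(Cl)c3)cc2F)ccn1` gives 7390 nM.

Compound 2 differs from compound 1 by 2,4-dichlorophenyl in place of 3-chloro-4-fluorophenyl on an amide-type nitrogen; this change gave a 2.8-fold higher number from compound 1 to compound 2 (0.44 log units; beyond the scatter). Compound 3 differs from compound 1 by diethylamino in place of dimethylamino on a saturated chain carbon, two bonds along the chain from an aromatic nitrogen, a change that gave a 4.7-fold higher number from compound 1 to compound 3 (0.67 log units; beyond the scatter); this is also how the core of compound 3 and compound 4 differs from the core of compound 1 and compound 2. Compound 3 carries the highest number of the three measured, but its gap to compound 2 lies within the scatter, so no order between those two is claimed.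

Compound 4 `CCN(CC)CCn1cnnc1-c1cc(Oc2ccc(NC(=O)Nc3ccc(Cl)cc3Cl)cc2F)ccn1` is not yet measured. It differs from compound 3 by 2,4-dichlorophenyl in place of 3-chloro-4-fluorophenyl on an amide-type nitrogen. The place of this change is the same, word for word, as in the pair compound 1 to compound 2, so it is the same change, seen once among measured pairs. That single instance, a 2.8-fold higher number from compound 1 to compound 2 (0.44 log units; beyond the scatter), together with the value of compound 3, 7390 nM, is all the expectation rests on. For compound 4 the expected step is a 2.4-fold higher number from compound 3 to compound 4 (0.39 log units; beyond the scatter). Compound 4 is therefore estimated at 18000 nM, with a range from 7000 nM to 50000 nM.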

Compound 4, half-maximal inhibitory concentration: 5380 nM
Compound 4: middle estimate off by 3.3-fold (0.52 log units), on the high side; the measured number lies below the stated range.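

In this assay, 2,4-dichlorophenyl in place of 3-chloro-4-fluorophenyl on the core of compound 3 gives a 1.4-fold lower number from compound 3 to compound 4 (0.14 log units; within the scatter), so the step seen on the core of compound 1 does not carry over: the same change on two cores in this assay, a 2.8-fold higher number (0.44 log units; beyond the scatter) from compound 1 to compound 2 and a 1.4-fold lower number (0.14 log units; within the scatter) from compound 3 to compound 4, 3.8-fold (0.58 log units) apart, beyond the scatter of two such steps

Diethylamino in place of dimethylamino, with 2,4-dichlorophenyl already present, gives a 1.2-fold higher number from compound 2 to compound 4 (0.09 log units; within the scatter), and this step does not match its earlier counterpart either: the same change on two cores in this assay, a 4.7-fold higher number (0.67 log units; beyond the scatter) from compound 1 to compound 3 and a 1.2-fold higher number (0.09 log units; within the scatter) from compound 2 to compound 4, 3.8-fold (0.58 log units) apart, beyond the scatter of two such steps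

Across these four compounds, the size of each step therefore depends on what sits at the other place, so the two changes cannot be treated as independent; this rests on one set of four compounds in one cell line and does not show why the steps differ or whether the same holds for other groups.

Still open, going by these compounds, is how an unsubstituted phenyl on the amide-type nitrogen would behave on either core. Also open, on these data alone, is whether a dipropylamino group or a longer chain in place of the diethylamino or dimethylamino arm would show the same dependence.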